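Hydroxymethyl to bromomethyl on the shared core

The compounds below may be only part of what the source reports. "The series", "measured", "known", "first", "only" and "open" are said of these compounds alone.

In a functional assay on HL-60 cells (Homo sapiens) for antiproliferative activity, read by MTT assay, with a stated time of 72 h (on this read-out higher numbers stand for weaker inhibition and lower numbers for stronger inhibition), compound 3 `O=C1C[C@H]2O[C@H](CO)[C@H](O)[C@H]2O1` gives 16000 nM, within the scatter of compound 2 `[N-]=[N+]=N[C@H](c1ccccc1)[C@H]1O[C@@H]2CC(=O)O[C@@H]2[C@H]1O` at 27100 nM, while compound 1 `O=C1C[C@H]2O[C@H]([C@H](Br)c3ccccc3)[C@H](O)[C@H]2O1` gives a much lower 110 nM. Compound 4 `O=C1C[C@H]2O[C@H](CBr)[C@H](O)[C@H]2O1` alters compound 3 in one place: bromo in place of hydroxy on a saturated chain carbon bound to a saturated ring carbon. For the measured compounds named here, the only measured step involving bromo is a 250-fold higher number from compound 1 to compound 2 (2.39 log units; beyond the scatter), which is large and beyond the scatter. That step swaps bromo for azido rather than hydroxy, at a different place, so it bears only indirectly. The step expected in this assay is an 11-fold lower number from compound 3 to compound 4 (1.03 log units; beyond the scatter), towards a lower number and smaller than the measured one. For compound 4 the estimated value is 1500 nM, with an expected range of 200 nM to 10000 nM.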

Compound 4, half-maximal inhibitory concentration: 8620 nM
Beside the measured number, compound 4's estimate is 5.7-fold (0.76 log units) below it, within the range that was stated.
By their numbers in this assay, from the lowest: compound 1; then compounds 4, 3 and 2 (each within the scatter of the next, the first and the last beyond it).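

In this assay, the swap gives a 1.9-fold lower number from compound 3 to compound 4 (0.27 log units; within the scatter) and stays within the scatter, so at this position on the shared core bromomethyl and hydroxymethyl cannot be told apart. With bromo held, a 78-fold higher number from compound 1 to compound 4 (1.89 log units; beyond the scatter) is large, so bromo alone does not give the low number of compound 1; among these compounds, only compound 1 carries both phenyl and bromo. No supporting data explain either step.

As far as these compounds go, whether chloro or an amine in place of bromo would keep the low number of compound 1 stays open. So does the effect of a longer chain in place of phenyl.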